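Swapping Methoxy for Chloro: Expected Cytotoxicity of Compound 3

The source may hold more compounds than are shown below. What is called first, only, known or untested is meant among the compounds shown, and "the series" means these compounds.

Compound 1 `Fc1cc(Nc2cc(Nc3ccc(Cl)cc3)ncn2)ccc1Oc1ccncc1-c1cccnc1`: 1610 nM
Compound 2 `COc1ccc(-n2nc(C(=O)Nc3ccc(Oc4ccncc4-c4cccnc4)c(F)c3)c3ccccc3c2=O)cc1`: 6800 nM

Both were tested in a functional assay on A549 cells (Homo sapiens) for cytotoxicity, read by MTT assay, with a stated time of 72 h; on this read-out lower numbers stand for stronger inhibition and higher numbers for weaker inhibition. Compound 2 gives 6800 nM, the higher of the two numbers, and the gap to compound 1 lies beyond the usual scatter. Compound 3 `O=C(Nc1ccc(Oc2ccncc2-c2cccnc2)c(F)c1)c1nn(-c2ccc(Cl)cc2)c(=O)c2ccccc12` differs from compound 2 by chloro in place of methoxy on an aromatic carbon. Among the compounds with values here, no measured pair shows this change, so the expectation rests on compound 2 alone. A small step is expected, within or near the scatter, if anything toward a lower number. Compound 3 is expected to give 5000 nM, with a range of 1500 nM to 15000 nM. This estimate means an expected step of a 1.4-fold lower number from compound 2 to compound 3 (0.13 log units; within the scatter).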

Compound 3, half-maximal inhibitory concentration: 1020 nM
Beside the measured number, compound 3's estimate is 4.9-fold (0.69 log units) above it; measured number outside the range, below it.
By their numbers in this assay, from the lowest: compounds 3 and 1 (each within the scatter of the next); then compound 2.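

In this assay, within the data shown here, replacing 4-methoxyphenyl with 4-chlorophenyl gives a 6.7-fold lower number from compound 2 to compound 3 (0.82 log units; beyond the scatter) in the first measured pair with this change. This shows that the number in this assay depends on which group sits on this aromatic carbon. No measurement shown here explains why the chloro compound gives the lower number. With only methoxy and chloro shown at this place, a single step cannot establish a trend. Going by these compounds, an amine, a nitrile or a carboxylic acid on this carbon remains open.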